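Hydroxy for Amino on Two Fused Diamino Cores

This account rests on a few compounds, and the source may have more. Where it says the series, first, only, none or still open, it means among the compounds named here.

Measured in an assay for inhibition of Dihydrofolate reductase (Homo sapiens); a higher number here means a more potent compound, by a factor of ten per unit of this negative logarithm, a lower number a less potent compound:
compound 1 `Nc1nc(O)c2c(Sc3ccc4ccccc4c3)cccc2n1`: 6.15
compound 2 `Cc1cccc2nc(N)nc(N)c12`: 6.09
compound 3 `Nc1nc(N)c2c(Sc3ccc4ccccc4c3)cccc2n1`: 6.92

Compound 1 and compound 3 share a core and differ only by hydroxy in place of amino on an aromatic carbon; in this assay this change gave a number 0.77 log units lower from compound 3 to compound 1 (beyond the scatter). Compound 2 has the lowest number of the three, within the scatter of compound 1 and beyond the scatter below compound 3. The difference between the core of compound 2 and the core of compound 3 is not broken down here.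

Compound 4 `Cc1cccc2nc(N)nc(O)c12` has not yet been measured. It differs from compound 2 by hydroxy in place of amino on an aromatic carbon, the same change in the same surroundings as from compound 3 to compound 1. The step from compound 2 to compound 4 in this assay is expected to be a number 0.79 log units lower from compound 2 to compound 4 (beyond the scatter), of a size like the earlier one, because that earlier change gave a number 0.77 log units lower from compound 3 to compound 1 (beyond the scatter). Compound 4 is therefore estimated at 5.3, expected to lie between 4.9 and 5.8.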

Compound 4, logarithm of the reciprocal of the active concentration, log(1/C): 4.8
For compound 4 the middle estimate is 0.50 log units above the measured one; the whole stated range lies above it.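

In this assay the new step is a number 1.29 log units lower from compound 2 to compound 4 (beyond the scatter), so hydroxy in place of amino on an aromatic carbon lowered the number on both cores shown. The direction of the change carried from one core to the other, but its size did not: the same change on two cores in this assay, a number 0.77 log units lower (beyond the scatter) from compound 3 to compound 1 and a number 1.29 log units lower (beyond the scatter) from compound 2 to compound 4, 0.52 log units apart, beyond the scatter of two such steps Two cores cannot show which difference between them sets the size of the step, nor whether the direction would hold on a third core.

The compounds shown leave open how other groups on the same aromatic carbon would compare on these two cores, such as methoxy or methylamino. They also leave open whether either of these groups would give steps that differ between the cores.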